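The source may report more compounds than this note shows. Statements on the series, on what has been measured and on what is new or still open speak of the compounds shown alone.

Compound 3 `Clc1ccc(/C=N/c2sc3c(c2-c2nc4ccccc4s2)CCCC3)c(Cl)c1` stands second highest of the three values measured in an ADME assay on cells (Rhabdomyosarcoma cell, Homo sapiens) for cytotoxicity, read by MTT assay, with a stated time of 72 h; on this read-out lower numbers stand for higher toxicity in this test and higher numbers for lower toxicity in this test. In this assay compound 3 gives 56.6 ug/mL, while compound 1 `Nc1sc2c(c1-c1nc3cc(Cl)ccc3s1)CCCC2` gives 43.5 ug/mL, a value within the scatter of that of compound 3, and compound 2 `Fc1ccc(/C=N/c2sc3c(c2-c2nc4ccccc4s2)CCC3)cc1` gives 290 ug/mL, a value well beyond the scatter above compound 3. Compound 4 `C(=C/c1ccccc1)\C=N\c1sc2c(c1-c1nc3ccccc3s1)CCCC2` differs from compound 3 by one change: 2-phenylethenyl in place of 2,4-dichlorophenyl on a carbon with a double bond to nitrogen. Among the measured compounds shown here, no measured pair shows this change, so its effect is unknown. Compound 4 is expected to show a 1.1-fold lower number from compound 3 to compound 4 (0.05 log units; within the scatter), a step of no clear direction and likely not beyond the scatter, given that compound 3 gives 56.6 ug/mL and compound 1 gives 43.5 ug/mL. The estimate for compound 4 in this assay is 50 ug/mL, within a range from 20 ug/mL to 150 ug/mL.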

Compound 4, half-maximal cytotoxic concentration: 207 ug/mL
Estimate against measurement, compound 4: 4.1-fold (0.62 log units) below; measured number outside the range, above it.
By their numbers in this assay, from the lowest: compounds 1 and 3 (each within the scatter of the next); then compounds 4 and 2 (each within the scatter of the next).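

In this assay, among the compounds shown here, the group on a carbon with a double bond to nitrogen proves to matter: 2-phenylethenyl in place of 2,4-dichlorophenyl gives a 3.7-fold higher number from compound 3 to compound 4 (0.56 log units; beyond the scatter) as the first single-change comparison at this place. The step is beyond the scatter, even though both groups have the same heavy-atom count and one six-membered aromatic ring. No available evidence explains the step. From the compounds shown here alone, it remains open whether the two chlorine atoms or the added double bond accounts for it. A plain phenyl or an aminophenyl group at this place could help separate the two.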